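Swapping the thiazole group of compound 2

This account rests on a few compounds, and the source may have more. Where it says the series, first, only, none or still open, it means among the compounds named here.

In an ADME assay on L6 cells (Rattus norvegicus) for cytotoxicity, read by resazurin assay, with a stated time of 72 h (a higher number here means a weaker inhibitor, a lower number a stronger inhibitor), compound 1 (`Cc1ccc(C(O)(c2ccc(Cl)cc2)c2cccnc2)cc1`) stands at 61000 nM as a true number. Compound 2 (`OC(c1ccc(Cl)cc1)(c1cccnc1)c1nccs1`) stands at > 100000 nM as a limit of the assay and not a number, so its place is known only as that limit. Compound 3 (`Nc1ncc(C(O)(c2ccc(Cl)cc2)c2cccnc2)s1`) carries 2-amino-1,3-thiazol-5-yl in place of 1,3-thiazol-2-yl on a saturated chain carbon bound to two aromatic carbons and an oxygen on a saturated carbon. Going by the values given here, the only measured step at that place (an at least 1.6-fold higher number from compound 1 to compound 2 (0.21 log units; that floor lies within the scatter)) put 1,3-thiazol-2-yl in place of 4-methylphenyl, and no step tests the amino group. Among the compounds with values here, with compound 1 at 61000 nM as the sole true number, a modest move to a lower number is expected in this assay. A result at the limit remains possible for compound 3. The estimated change is small (an at least 1.4-fold lower number from compound 2 to compound 3 (0.15 log units; that floor lies within the scatter)). For compound 3 the expected value is 70000 nM (estimated range 25000 nM to 120000 nM).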

Compound 3, half-maximal inhibitory concentration: 56000 nM
Beside the measured number, compound 3's estimate is 1.3-fold (0.10 log units) above it; the range from low to high includes it.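

In this assay, this position now holds a second true number, and 2-amino-1,3-thiazol-5-yl in place of 4-methylphenyl gives a 1.1-fold lower number from compound 1 to compound 3 (0.04 log units; within the scatter), so these two groups cannot be told apart here. Compound 2 is known only as a limit and not as a number: the limit of > 100000 nM in this assay, at which 1 of the 3 values shown sits. The change from 1,3-thiazol-2-yl to 2-amino-1,3-thiazol-5-yl reads as an at least 1.7-fold lower number from compound 2 to compound 3 (0.25 log units; that floor lies within the scatter), so this swap of thiazole groups shows no shift clear of the scatter.

The compounds shown leave open what the amino group adds on its own, apart from the change from a 2-yl to a 5-yl thiazole. As far as these compounds go, it also remains open whether a carboxylic acid or an acetamide in its place on the thiazole would move the number clear of the scatter.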